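This account rests on a few compounds, and the source may have more. Where it says the series, first, only, none or still open, it means among the compounds named here.

Measured compounds in an assay on HEK293 cells for inhibition of Steryl-sulfatase (Homo sapiens), tested at 1 uM; on this read-out lower numbers stand for a weaker effect and higher numbers for a stronger effect at the one concentration tested:
Compound 1, `NS(=O)(=O)Oc1ccc2c(c1)CN(C(=O)c1cccc(N(Cc3ccccc3)Cc3ccco3)c1)CC2`, gives 90.5%.
Compound 2, `CCCN(CCC)c1cccc(C(=O)N2CCc3ccc(OS(N)(=O)=O)cc3C2)c1`, gives 54.8%.
Compound 3, `CN(CCN1CCCCC1)c1cccc(C(=O)N2CCc3ccc(OS(N)(=O)=O)cc3C2)c1`, gives 30.8%.

Compound 3 sits at the bottom of these three numbers: compound 2 stands above it by a step that lies beyond the scatter, and compound 1 stands furthest above it. Among the measured compounds shown here, the one single-point step that has been measured is a number 24 percentage points lower from compound 2 to compound 3 (beyond the scatter), a modest fall.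

Compound 4, `CCN(Cc1ccccc1)c1cccc(C(=O)N2CCc3ccc(OS(N)(=O)=O)cc3C2)c1`, has not been measured yet. It differs from compound 3 in one place: benzyl(ethyl)amino in place of methyl(2-(piperidin-1-yl)ethyl)amino on an aromatic carbon. For the measured compounds named here, the only step that bears on this change is the one from compound 2 to compound 3, which was worth a modest fall; compound 4 undoes that piece and puts in a benzyl(ethyl)amino group instead. Going by the values given here, compound 1, which carries a benzyl on the same nitrogen together with a furan-2-ylmethyl, gives a higher number than compound 2, though no single-point step connects those two. The author therefore expects a rise in this assay from compound 3 to compound 4 of about a number 41.2 percentage points higher from compound 3 to compound 4 (beyond the scatter). For compound 4 the estimated value is 72%, with a range from 52% to 90%.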

Compound 4, a percentage reported as inhibition, at one concentration (the size of the read-out at that concentration, not a potency): 69%
The estimate for compound 4 lay 3 percentage points above the measured number; measured number inside the range.
By their numbers in this assay, from the lowest: compound 3; then compound 2; then compound 4; then compound 1.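

In this assay, benzyl(ethyl)amino on this aromatic carbon gives a number 38.2 percentage points higher from compound 3 to compound 4 (beyond the scatter), and this large step comes with no change in the count of 10 heavy atoms, so that count alone does not separate the two groups; what differs is a six-membered aromatic ring of carbon only in place of a six-membered non-aromatic ring with 1 hetero atom. The same group also improves on the plain dialkyl amine, with a number 14.2 percentage points higher from compound 2 to compound 4 (beyond the scatter), while the change at the far end of the substituent gives a number 21.5 percentage points lower from compound 1 to compound 4 (beyond the scatter), so the read-out at this position responds to both groups on the nitrogen, not only to the benzyl. The data shown offer no measurement that accounts for these differences.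

As far as these compounds go, whether the gain belongs to the aromatic ring itself stays open, and a cyclohexylmethyl group in place of benzyl would address that. From the compounds shown here alone, it is equally open how far a second aromatic group on the nitrogen carries the higher number, which a dibenzylamino group or a thiophen-2-ylmethyl group in place of furan-2-ylmethyl would test.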